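Cyclopentyl to Cyclohexyl: An Expectation for Compound 4

The source may report more compounds than this note shows. Statements on the series, on what has been measured and on what is new or still open speak of the compounds shown alone.

Three compounds have been measured in a functional assay on M21 cells (Homo sapiens) for inhibition, read by sulforhodamine B assay, with a stated time of 48 h; on this read-out lower numbers stand for stronger inhibition of growth and higher numbers for weaker inhibition of growth:

compound 1, `O=C(CCl)NC(=O)Nc1ccc(OC2CCCC2)cc1`, gives 2900 nM
compound 2, `O=C(CCl)NC(=O)Nc1cccc(OC2CCCC2)c1`, gives 3500 nM
compound 3, `O=C(CCl)NC(=O)Nc1ccc(OC2CCCCC2)cc1`, gives 5000 nM

Compound 3 differs from compound 1 by cyclohexyl in place of cyclopentyl on an oxygen on an aromatic ring; in this assay this gives a 1.7-fold higher number from compound 1 to compound 3 (0.24 log units; within the scatter). Compound 2 has the same atoms as compound 1, joined differently, and the difference between the two cores is not broken down here. Its value in this assay lies within the scatter of both compound 1 and compound 3, so no order among the three can be read from these numbers.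

Compound 4, `O=C(CCl)NC(=O)Nc1cccc(OC2CCCCC2)c1`, has not yet been measured. It differs from compound 2 by cyclohexyl in place of cyclopentyl on an oxygen on an aromatic ring, the same change, at the same place, as from compound 1 to compound 3. A step of a 1.6-fold higher number from compound 2 to compound 4 (0.20 log units; within the scatter) is expected in this assay, set beside the earlier step, because the same change gave a 1.7-fold higher number from compound 1 to compound 3 (0.24 log units; within the scatter) and because compound 2 gives 3500 nM. Compound 4 is therefore estimated to give 5500 nM in this assay, expected to fall between 3000 nM and 10000 nM.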

Compound 4, concentration for 50% growth inhibition: 2700 nM
Estimate against measurement, compound 4: 2.0-fold (0.31 log units) above, and the stated range ends above it.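

In this assay, cyclohexyl in place of cyclopentyl on an oxygen on an aromatic ring gives a 1.3-fold lower number from compound 2 to compound 4 (0.11 log units; within the scatter), and the two readings of this change can be set side by side: the same change on two cores in this assay, a 1.7-fold higher number (0.24 log units; within the scatter) from compound 1 to compound 3 and a 1.3-fold lower number (0.11 log units; within the scatter) from compound 2 to compound 4, 2.2-fold (0.35 log units) apart, within the scatter of two such steps

The steps point in opposite directions on paper, yet neither step nor the gap separating them can be told from the scatter, so the change carries from the core of compound 1 to the core of compound 2 with no measurable difference. This does not show that the change is without effect, or that the two cores respond alike, since two pairs at this level of scatter cannot establish either.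

The compounds shown leave open whether a group other than cyclopentyl or cyclohexyl at this oxygen, such as a longer chain like hexyl or a chain ending in an amine, would give a step that stands clear of the scatter. They also leave open how far any such step would carry across the two cores.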